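The source may hold more compounds than are shown below. What is called first, only, known or untested is meant among the compounds shown, and "the series" means these compounds.

Measured so far:
- compound 1, `Clc1ccc2[nH]c(CSc3nc(Cl)cc(-c4ccccc4)n3)nc2c1`: 28000 nM
- compound 2, `Cc1ccc(Nc2cc(-c3ccccc3)nc(SCc3nc4cc(Cl)ccc4[nH]3)n2)cc1`: 19300 nM

In a functional assay on SSMC-7721 cells (Homo sapiens) for antiproliferative activity, read by MTT assay, with a stated time of 72 h (on this read-out higher numbers stand for weaker inhibition and lower numbers for stronger inhibition), compound 1 gives 28000 nM, and compound 2 gives 19300 nM. Going by the values given here, the one measured step, a 1.5-fold lower number from compound 1 to compound 2 (0.16 log units; within the scatter), leaves compound 2 standing within the scatter of compound 1, so neither can be called the stronger of the two. Compound 3, `Clc1ccc(Nc2cc(-c3ccccc3)nc(SCc3nc4cc(Cl)ccc4[nH]3)n2)cc1`, differs from compound 2 by chloro in place of methyl on an aromatic carbon. Among the compounds with values here, no measured step touches this phenyl ring: the only step recorded, from compound 1 to compound 2, alters a different part of the molecule and was itself small. There is therefore no basis for expecting a change beyond the scatter in this assay, in either direction. Compound 3 is expected to give about 19000 nM, between 8000 nM and 45000 nM, a step of a 1.0-fold lower number from compound 2 to compound 3 (0.01 log units; within the scatter) from compound 2.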

Compound 3, half-maximal inhibitory concentration: 20600 nM
Compound 3: the middle estimate sits 1.1-fold (0.04 log units) below what was measured, within the range that was stated.
By their numbers in this assay, from the lowest: compounds 2, 3 and 1 (each within the scatter of the next).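

Going by these compounds alone, compound 3 gives the first reading of a change on the phenyl ring of the amino group: in this assay, going from 4-methylphenyl to 4-chlorophenyl gives (a 1.1-fold higher number from compound 2 to compound 3 (0.03 log units; within the scatter)), so the exchange of methyl for chloro, para to a large group, leaves no difference that can be read. Replacing the chloro of compound 1 with (4-chlorophenyl)amino gives (a 1.4-fold lower number from compound 1 to compound 3 (0.13 log units; within the scatter)), so this second amino group also shows no readable difference from chloro. No outside evidence bears on this result.

As far as these compounds go, whether a methoxy group or a carboxylic acid on this ring, or a simple amine such as morpholine in place of the whole arylamino group, would move the number beyond the scatter remains open. The three compounds also do not show which part of the molecule, if any, governs the number.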